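Thiosemicarbazide series: ring swap at the thiocarbonyl carbon

This account rests on a few compounds, and the source may have more. Where it says the series, first, only, none or still open, it means among the compounds named here.

Measured so far in a functional assay on MCF7 cells (Homo sapiens) for cytotoxicity, read by MTT assay, with a stated time of 72 h, tested at 1 uM; a lower number here means less inhibition of growth, a higher number more inhibition of growth at the concentration tested:
compound 1 `N/C(=N\NC(=S)N1CCCCCC1)c1ccccn1`, 25.3%
compound 2 `Cc1cccc(/C(N)=N/NC(=S)N2CCSCC2)n1`, 7.3%
compound 3 `N/C(=N\NC(=S)N1CCSCC1)c1ccccn1`, 16.3%

Compound 2 gives the lowest of the three numbers. Its nearest neighbour is compound 3, with a number 9 percentage points higher from compound 2 to compound 3 (within the scatter); compound 1 lies furthest away, beyond the scatter. Compound 4 `Cc1cccc(/C(N)=N/NC(=S)N2CCCC2)n1` differs from compound 2 by pyrrolidin-1-yl in place of thiomorpholin-4-yl on a thiocarbonyl carbon. Going by the values given here, no measured step covers this change directly; compound 1 and compound 3 differ at the same place, and their two values lie apart beyond the scatter, which gives some room for movement. Compound 4 is expected to come out near 12%, between 2% and 26%. This corresponds to an expected step of a number 4.7 percentage points higher from compound 2 to compound 4 (within the scatter), not clearly beyond the scatter.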

Compound 4, percent growth inhibition at one concentration: 17.4%
The estimate for compound 4 lay 5.4 percentage points below the measured number; the measured number falls inside the stated range.
By their numbers in this assay, from the lowest: compounds 2, 3, 4 and 1 (each within the scatter of the next, the first and the last beyond it).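

In this assay, pyrrolidin-1-yl in place of thiomorpholin-4-yl on the thiocarbonyl carbon gives a number 10.1 percentage points higher from compound 2 to compound 4 (beyond the scatter), a modest change. This is the first listed step at this position, and it shows that the position responds to a ring swap while the methyl group stays in place. No available evidence bears on the reason for this step.

Open, going by these compounds, is how morpholin-4-yl or an open-chain diethylamino group would compare on this thiocarbonyl carbon. Also open, on these data alone, is whether the same ring swap gives a similar step on the core of compound 3.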